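Working notes on three measured compounds and a fourth

This account rests on a few compounds, and the source may have more. Where it says the series, first, only, none or still open, it means among the compounds named here.

Measured so far in a functional assay on HeLa cells (Homo sapiens) for antiproliferative activity, read by MTT assay, with a stated time of 48 h; a higher number here means a weaker inhibitor, a lower number a stronger inhibitor:
compound 1, `CNCC(=O)Nc1cc(OC)ccc1C(=O)c1ccc(OC)c2c1OC(C)(C)C=C2`, gives 870 nM
compound 2, `CNCC(=O)Nc1cc(OC)ccc1C(=O)c1ccc(OC)c2c1C=CC(C)(C)O2`, gives 2170 nM
compound 3, `CCNCC(=O)Nc1cc(OC)ccc1C(=O)c1ccc(OC)c2c1OC(C)(C)C=C2`, gives 2690 nM

Compound 1 and compound 2 are built from the same atoms joined differently; the difference between the two cores is not broken down here, and their two numbers lie beyond the scatter of each other. Compound 3 carries, relative to compound 1, the change (methyl in place of hydrogen on a saturated chain carbon bound to an amine nitrogen), and that step reads a 3.1-fold higher number from compound 1 to compound 3 (0.49 log units; beyond the scatter). Compound 2 and compound 3 give numbers within the usual scatter of each other.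

Compound 4, `CCNCC(=O)Nc1cc(OC)ccc1C(=O)c1ccc(OC)c2c1C=CC(C)(C)O2`, is not yet measured in this assay. Going by the values given here, it differs from compound 2 by methyl in place of hydrogen on a saturated chain carbon bound to an amine nitrogen, the same change in the same place as the one from compound 1 to compound 3. Among the compounds with values here, only one instance of this change has been measured, so the expectation rests on a single step. For compound 4 the expected step is a 3.0-fold higher number from compound 2 to compound 4 (0.48 log units; beyond the scatter), because the same change on the other core gave a 3.1-fold higher number from compound 1 to compound 3 (0.49 log units; beyond the scatter). Compound 4 is therefore estimated at 6500 nM, with an expected range from 3000 nM to 15000 nM.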

Compound 4, half-maximal inhibitory concentration: 4270 nM
Compound 4: middle estimate off by 1.5-fold (0.18 log units), on the high side; low and high end bracket the measured number.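

In this assay, methyl in place of hydrogen on a saturated chain carbon bound to an amine nitrogen gives a 2.0-fold higher number from compound 2 to compound 4 (0.29 log units; within the scatter), so on this core the step alone does not stand clear of the scatter. Set beside the earlier step, the two do not differ measurably: the same change on two cores in this assay, a 3.1-fold higher number (0.49 log units; beyond the scatter) from compound 1 to compound 3 and a 2.0-fold higher number (0.29 log units; within the scatter) from compound 2 to compound 4, 1.6-fold (0.20 log units) apart, within the scatter of two such steps The change therefore points the same way on both cores and gives no sign of depending on the core, but two pairs cannot show that the steps are equal or that the change would carry to any further core.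

The compounds shown leave open whether the trend from methylamino to ethylamino continues to a longer chain such as propylamino or a branched one such as isopropylamino. They also leave open how an unsubstituted primary amine or a ring amine such as pyrrolidine would compare on either core.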